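The source may hold more compounds than are shown below. What is called first, only, known or untested is meant among the compounds shown, and "the series" means these compounds.

Series notes, metabolic stability. Going by the values given here, compound 1 `NS(=O)(=O)c1cc(-c2nnc(CCl)o2)c(Cl)cc1SCc1ccccc1` is the lower of the two compounds measured so far in an ADME assay on microsomes from liver (Homo sapiens) for metabolic stability, read by LC-MS, using NADPH, tested at 5 uM (on this read-out lower numbers stand for a shorter-lived compound and higher numbers for a longer-lived compound), where compound 1 gives 0.235 h. Compound 2 `NS(=O)(=O)c1cc(-c2nnc(CN3CCC(Cc4ccccc4)CC3)o2)c(Cl)cc1SCc1ccccc1` sits nearest, and in this assay compound 2 gives 0.363 h, a gap that stays within the scatter, so the two are read as alike on this read-out. Among the compounds with values here, no step between measured compounds that differ in one place has been observed, so no directional effect of a single change is established within the set.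

Compound 3 `NS(=O)(=O)c1cc(-c2nnc(CNC(=O)c3ccccc3)o2)c(Cl)cc1SCc1ccccc1` is the next compound to be measured in this assay and differs from compound 1 as follows: benzamido in place of chloro on a saturated chain carbon bound to an aromatic carbon.

Within the data shown here, with no measured step to lean on, only the two values so far anchor an expectation. The change from compound 1 to compound 3 is expected to give a 1.4-fold higher number from compound 1 to compound 3 (0.15 log units; within the scatter), a shift that would not clearly exceed the scatter, partly because compound 2 gives 0.363 h for a different replacement at the same carbon. Compound 3 is therefore estimated at 0.33 h in this assay, with a range from 0.14 h to 0.85 h.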

Compound 3, half-life: 0.187 h
For compound 3 the middle estimate is 1.8-fold (0.25 log units) above the measured one, within the range that was stated.
By their numbers in this assay, from the lowest: compounds 3, 1 and 2 (each within the scatter of the next).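

Benzamido in place of chloro on a saturated chain carbon bound to an aromatic carbon gives a 1.3-fold lower number from compound 1 to compound 3 (0.10 log units; within the scatter) in this assay, the first single-place step read at this position. The entering group brings a six-membered aromatic ring, a hydrogen-bond donor and a hydrogen-bond acceptor, yet compound 1 and compound 3 still read as alike, so this exchange shows no measurable effect on the half-life. No measurement on hand speaks to the reason for this result.

From the compounds shown here alone, whether any group at this carbon can move the half-life beyond the scatter remains open. A carboxylic acid or a primary amine in place of benzamido would test this, and an acetamido group would separate the amide from its aromatic ring.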